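Removing the methoxy group from the cinnamoyl ring of compound 3

The compounds below may be only part of what the source reports. "The series", "measured", "known", "first", "only" and "open" are said of these compounds alone.

Three chalcone-type compounds have been examined in a functional assay on Caco-2 cells (Homo sapiens), read by fluorescence and BrdU incorporation, with a stated time of 48 h, tested at 10 uM; on this read-out higher numbers stand for a weaker effect at the one concentration tested and lower numbers for a stronger effect. Compound 1 `COc1cc(O)c(C(=O)/C=C/c2ccc(F)cc2)c(OC)c1` gives 49% in this assay, compound 2 `COc1cc(OC)c(C(=O)/C=C/c2ccccc2SC)c(OC)c1` gives 36%, and compound 3 `COc1cccc(/C=C/C(=O)c2c(OC)cc(OC)cc2OC)c1` gives 31%. The number for compound 3 lies beyond the scatter from that of compound 1, but its gap to compound 2 lies within the scatter, so the two cannot be ordered. Going by the values given here, the single step between measured compounds that differ in one place, a number 5 percentage points lower from compound 2 to compound 3 (within the scatter), exchanged the whole aryl group on the chain and left the number essentially unchanged.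

Compound 4 `COc1cc(OC)c(C(=O)/C=C/c2ccccc2)c(OC)c1` differs from compound 3 in one place: hydrogen in place of methoxy on an aromatic carbon. Among the compounds with values here, no measured pair shows this exact change, and the only step that touches the same aryl ring is the small one from compound 2 to compound 3, which suggests that substitution on that ring has, so far, moved this assay little. Compound 4 is therefore expected to sit close to compound 3, the estimated step being a number 7 percentage points higher from compound 3 to compound 4 (within the scatter), with a slight lean toward a higher number. The estimate for compound 4 is 38%, with a range from 22% to 56%.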

Compound 4, a percentage reported as activity, at one concentration (the size of the read-out at that concentration, not a potency): 38%
Compound 4: middle estimate and measured number agree at the digits printed, and the stated range covers the measured number.
By their numbers in this assay, from the lowest: compounds 3, 2 and 4 (each within the scatter of the next); then compound 1.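

In this assay the unsubstituted phenyl ring of compound 4 gives the series its first reference point on this ring: the change from 3-methoxyphenyl to phenyl gives a number 7 percentage points higher from compound 3 to compound 4 (within the scatter) and the loss of methylsulfanyl gives a number 2 percentage points higher from compound 2 to compound 4 (within the scatter) on the same comparison. Going by these compounds alone, until now, the only step on this ring had exchanged one substituted aryl group for another, whereas these two steps show that compounds 2, 3 and 4 cannot be ordered whether the ring carries methoxy, carries methylsulfanyl or carries neither, and that neither group is required for a number in this range at the one concentration tested. Nothing available bears on why removing either group leaves the number within the scatter.

On these data alone, all the steps on this ring remain within the scatter, and it stays open whether a different kind of group there, such as an amine or a carboxylic acid, would move the number beyond it. Compound 1 differs from compound 4 in more than one place, and the contribution of its hydroxy group and of its fluorine each remains unresolved.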